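Adding a chloro group to compound 3

The source may hold more compounds than are shown below. What is called first, only, known or untested is meant among the compounds shown, and "the series" means these compounds.

These benzamides were tested for how strongly they hold back cancer cell growth. In a functional assay on KB cells (Homo sapiens) for antiproliferative activity, read by sulforhodamine B assay, with a stated time of 48 h (a lower number here means a stronger inhibitor of growth, a higher number a weaker inhibitor of growth), compound 1 `COc1ccc(S(=O)(=O)Nc2ccc(CCc3ccc(C(=O)Nc4ccccc4N)cc3)cc2)cc1` gives > 10000 nM, which is a limit of the assay and not a number. Compound 2 `COc1ccc(S(=O)(=O)Nc2cccc(CCc3ccc(C(=O)Nc4ccccc4N)cc3)c2)cc1` gives 678 nM, and compound 3 `Nc1ccccc1NC(=O)c1ccc(CCc2ccccc2NS(=O)(=O)c2ccccc2)cc1` gives 456 nM. The numbers for these last two lie within the usual scatter of each other, so compound 3 stands level with compound 2 in this assay.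

Compound 4 `Nc1ccccc1NC(=O)c1ccc(CCc2ccccc2NS(=O)(=O)c2ccc(Cl)cc2)cc1` has not yet been measured. It differs from compound 3 at a single place, where phenyl becomes 4-chlorophenyl: chloro in place of hydrogen on an aromatic carbon, para to a large group (chloro in place of hydrogen on an aromatic carbon). Among the measured compounds shown here, no measured pair here shows what this change does, so the expectation starts from compound 3 at 456 nM and foresees no shift beyond the scatter, in either direction. The estimated step is a 1.1-fold lower number from compound 3 to compound 4 (0.04 log units; within the scatter). For compound 4 the expected value is 420 nM, with an estimated range of 170 nM to 1100 nM.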

Compound 4, concentration for 50% growth inhibition: 448 nM
For compound 4 the middle estimate is 1.1-fold (0.03 log units) below the measured one, within the range that was stated.
By their numbers in this assay, from the lowest: compounds 4, 3 and 2 (each within the scatter of the next). At a limit, above all of these: compound 1.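

In this assay, chloro in place of hydrogen on the phenylsulfonyl ring gives a 1.0-fold lower number from compound 3 to compound 4 (0.01 log units; within the scatter). Among the compounds shown here, this is the first measured pair for this change, and it shows that the aromatic carbon para to a large group can carry a chlorine atom while the number stays level with that of the unsubstituted phenyl. Nothing measured here says why the number holds level.

What the compounds shown leave open is whether this position would accept a group of another kind, such as an amine, a carboxylic acid or a longer chain, as readily as it accepts chloro. They also leave open whether chloro at another carbon of the same ring would give a number level with compound 3.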